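A few compounds are considered here, and "the series" means these few. Any claim that something is new, unique, unknown or untested is made for them only; others in the source may bear on it.

In a functional assay on HeLa cells (Homo sapiens) for cytotoxicity, read by MTT assay, with a stated time of 48 h (on this read-out lower numbers stand for stronger inhibition and higher numbers for weaker inhibition), compound 1 `COc1cc(/C=C/C(=O)C2=C(/C=C/c3ccc(O)c(OC)c3)NC(=S)NC2c2ccccc2)ccc1O` gives 25000 nM, compound 2 `COc1cc(/C=C/C(=O)C2=C(/C=C/c3ccc(O)c(OC)c3)NC(=S)NC2c2ccc(C)cc2)ccc1O` gives 25000 nM and compound 3 `COc1cc(/C=C/C(=O)C2=C(/C=C/c3ccc(O)c(OC)c3)NC(=S)NC2c2ccccc2O)ccc1O` gives 25000 nM, so compound 3 stands level with the other two. The next candidate is compound 4 `COc1cc(/C=C/C(=O)C2=C(/C=C/c3ccc(O)c(OC)c3)NC(=S)NC2c2ccc(N(C)C)cc2)ccc1O`. It carries 4-(dimethylamino)phenyl in place of 2-hydroxyphenyl on a saturated ring carbon.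

Within the data shown here, three measured steps bear on this change. Two add a small group to the aromatic ring on that same carbon: no change at the digits printed from compound 1 to compound 2 (within the scatter) and no change at the digits printed from compound 1 to compound 3 (within the scatter). The third exchanges one substituted phenyl group for another, which comes closest to the new change: no change at the digits printed from compound 2 to compound 3 (within the scatter). None of these steps goes beyond the scatter. Among the measured compounds shown here, no measured compound carries a dimethylamino group, however, so the expectation is an extrapolation and its range is kept wide.

The expected step in this assay is no change at the digits printed from compound 3 to compound 4 (within the scatter), meaning that no shift in either direction is expected beyond the scatter. Compound 4 is estimated at 25000 nM, with an expected range of 11000 nM to 45000 nM.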

Compound 4, half-maximal inhibitory concentration: 12500 nM
For compound 4 the middle estimate is 2.0-fold (0.30 log units) above the measured one; the range from low to high includes it.
By their numbers in this assay, from the lowest: compounds 4, 1, 2 and 3 (each within the scatter of the next).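

In this assay the steps of a 2.0-fold lower number from compound 3 to compound 4 (0.30 log units; within the scatter) and a 2.0-fold lower number from compound 2 to compound 4 (0.30 log units; within the scatter) and a 2.0-fold lower number from compound 1 to compound 4 (0.30 log units; within the scatter) extend the earlier picture to a group that carries nitrogen. The saturated ring carbon thus takes 4-(dimethylamino)phenyl, with 9 heavy atoms against 7 for 2-hydroxyphenyl and no hydrogen-bond donor, and all four compounds still stay within the scatter of one another. Nothing available here accounts for the small difference in the printed numbers.

The compounds shown leave open whether any group on this carbon can move the value beyond the scatter, such as a phenyl ring bearing a carboxylic acid or a longer alkyl chain. They also leave open what happens when the 2-(4-hydroxy-3-methoxyphenyl)ethenyl group, the same in all four compounds, gives way to another group.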